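Sugar in place of a diol on a triazole arm

The compounds below may be only part of what the source reports. "The series", "measured", "known", "first", "only" and "open" are said of these compounds alone.

Measured compounds:
compound 1 `O=C1c2c[n+]([O-])c3ccccc3c2C(=O)c2[nH]c3ccccc3c21` with 660 nM
compound 2 `O=C1c2c[n+]([O-])c3ccccc3c2C(=O)c2c1c1ccccc1n2Cc1cn(CC(O)CO)nn1` with 440 nM
compound 3 `CN1CCN(CCCn2c3c(c4ccccc42)C(=O)c2c[n+]([O-])c4ccccc4c2C3=O)CC1` with 470 nM

All three were measured in a functional assay on A-375 cells (Homo sapiens) for cytotoxicity, read by MTT assay, with a stated time of 72 h; on this read-out higher numbers stand for weaker inhibition and lower numbers for stronger inhibition. Compound 2 gives the lowest of the three numbers, yet its two neighbours sit close: the gap a 1.5-fold lower number from compound 1 to compound 2 (0.18 log units; within the scatter) and the gap a 1.1-fold higher number from compound 2 to compound 3 (0.03 log units; within the scatter) are both within the scatter, so no order among these compounds can be claimed.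

Compound 4 `O=C1c2c[n+]([O-])c3ccccc3c2C(=O)c2c1c1ccccc1n2Cc1cn([C@@H]2O[C@H](CO)[C@@H](O)[C@H](O)[C@H]2O)nn1` has not been measured. It differs from compound 2 in one place: 3,4,5-trihydroxy-6-(hydroxymethyl)oxan-2-yl in place of 2,3-dihydroxypropyl on an aromatic nitrogen.

Among the compounds with values here, no measured step changes the group on the triazole nitrogen itself. The nearest comparisons are the replacement of the whole arm in a 1.1-fold higher number from compound 2 to compound 3 (0.03 log units; within the scatter) and its addition in a 1.5-fold lower number from compound 1 to compound 2 (0.18 log units; within the scatter), both within the scatter. The account therefore expects no step beyond the scatter in this assay for compound 4, neither up nor down.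

Compound 4 is estimated at 500 nM, with a range from 250 nM to 1000 nM, which means an expected step of a 1.1-fold higher number from compound 2 to compound 4 (0.06 log units; within the scatter).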

Compound 4, half-maximal inhibitory concentration: 230 nM
Compound 4: middle estimate off by 2.2-fold (0.34 log units), on the high side; the whole stated range lies above it.
By their numbers in this assay, from the lowest: compounds 4, 2, 3 and 1 (each within the scatter of the next, the first and the last beyond it).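

In this assay, the group on the aromatic nitrogen of the triazole was changed directly, with 3,4,5-trihydroxy-6-(hydroxymethyl)oxan-2-yl in place of 2,3-dihydroxypropyl, and this gives a 1.9-fold lower number from compound 2 to compound 4 (0.28 log units; within the scatter), so no order between the two compounds can be claimed. Within the data shown here, the result shows that this position accepts a group with a six-membered non-aromatic ring, 11 heavy atoms and 5 defined stereocentres without a step beyond the scatter, whereas the earlier compounds showed only the 2,3-dihydroxypropyl group there. Nothing available explains the size or direction of this step.

The compounds shown leave open how an amine, a carboxylic acid or a longer unbranched alkyl chain on this triazole nitrogen would behave. They also leave open whether the same oxane ring with inverted stereocentres would give a similar number.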